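Moving the halogen on the urea aryl ring of compound 3

A few compounds are considered here, and "the series" means these few. Any claim that something is new, unique, unknown or untested is made for them only; others in the source may bear on it.

Three compounds that share one core were compared in a functional assay on U-87MG ATCC cells for inhibition, with U-87 MG (Homo sapiens) as the target, read by MTT assay, with a stated time of 72 h; on this read-out lower numbers stand for stronger inhibition and higher numbers for weaker inhibition. Compound 1 `C=C[C@]1(C)C[C@@H](OC(=O)CNC(=O)Nc2cccc(Br)c2)[C@]2(C)[C@H](C)CC[C@]3(CCC(=O)[C@H]32)[C@@H](C)[C@@H]1O` gives > 10000 nM, which is a limit of the assay and not a number. Compound 2 `C=C[C@]1(C)C[C@@H](OC(=O)CNC(=O)NC(=O)c2cccc(F)c2)[C@]2(C)[C@H](C)CC[C@]3(CCC(=O)[C@H]32)[C@@H](C)[C@@H]1O` likewise stops at a limit, > 10000 nM. Compound 3 `C=C[C@]1(C)C[C@@H](OC(=O)CNC(=O)Nc2ccc(Cl)cc2)[C@]2(C)[C@H](C)CC[C@]3(CCC(=O)[C@H]32)[C@@H](C)[C@@H]1O` also reaches only a limit, > 10000 nM. Because (the limit of > 10000 nM in this assay, at which 3 of the 3 values shown sit), the steps a step that the two limits leave unreadable from compound 1 to compound 2, a step that the two limits leave unreadable from compound 1 to compound 3 and a step that the two limits leave unreadable from compound 2 to compound 3 cannot be read in size or direction. Compound 4 `C=C[C@]1(C)C[C@@H](OC(=O)CNC(=O)Nc2ccccc2Br)[C@]2(C)[C@H](C)CC[C@]3(CCC(=O)[C@H]32)[C@@H](C)[C@@H]1O` differs from compound 3 by 2-bromophenyl in place of 4-chlorophenyl on an amide-type nitrogen. No readable measured step bears on this change, so no shift beyond the scatter is expected, and the expected step is a step that the limit leaves unreadable from compound 3 to compound 4. Compound 4 is therefore expected to give about 20000 nM, between 5000 nM and 100000 nM, most likely again reported only as a limit.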

Compound 4, half-maximal inhibitory concentration: > 10000 nM
Compound 4: no number, only a limit; the forecaster's own chance of this, stated with the estimate: 85%; the middle value is on the limit's open side.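

Compound 4 adds no readable step against compound 1, compound 2 or compound 3, because all four stop at the same limit, not a number: the limit of > 10000 nM in this assay, at which 4 of the 4 values shown sit.

On these data alone, whether any of these groups on the amide-type nitrogen changes inhibition in this assay stays open.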